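The source may hold more compounds than are shown below. What is called first, only, known or untested is meant among the compounds shown, and "the series" means these compounds.

Compound 1 `COc1ccc(-c2cc3nccc(-c4cc(OC)c(OC)c(OC)c4)n3n2)cc1N`: in a functional assay on HeLa cells (Homo sapiens) for inhibition, read by CCK-8 assay, with a stated time of 48 h (on this read-out lower numbers stand for stronger inhibition and higher numbers for weaker inhibition), compound 1 gives 283 nM.
Compound 2 `COc1cc(-c2ccnc3cc(-c4ccc(Cl)cc4)nn23)cc(OC)c1OC`: compound 2 gives 1490 nM.
Compound 3 `COc1cc(-c2ccnc3c(-c4ccc(C)cc4)cnn23)cc(OC)c1OC`: compound 3 reaches only the limit > 10000 nM, the point at which (the limit of > 10000 nM in this assay, at which 1 of the 3 values shown sits).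

Among the two numbers, compound 1 stands lowest; its nearest neighbour is compound 2, with a 5.3-fold higher number from compound 1 to compound 2 (0.72 log units; beyond the scatter). Compound 4 `COc1cc(-c2ccnc3cc(-c4ccc(C(C)=O)cc4)nn23)cc(OC)c1OC` has not been measured. It differs from compound 1 by 4-acetylphenyl in place of 3-amino-4-methoxyphenyl on an aromatic carbon. Among the measured compounds shown here, the one measured step that bears on this change is the exchange of the same group at the same place for 4-chlorophenyl, which gave the modest rise from compound 1 to compound 2 noted above. A step of similar size and direction is expected for compound 4, namely a 4.2-fold higher number from compound 1 to compound 4 (0.63 log units; beyond the scatter). Compound 4 is therefore estimated at 1200 nM, with a likely range from 400 nM to 4000 nM.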

Compound 4, half-maximal inhibitory concentration: 1810 nM
The estimate for compound 4 lay 1.5-fold (0.18 log units) below the measured number; low and high end bracket the measured number.
By their numbers in this assay, from the lowest: compound 1; then compounds 2 and 4 (each within the scatter of the next). At a limit, above all of these: compound 3.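

In this assay, 4-acetylphenyl on this carbon, next to the ring nitrogen, also falls short of the 3-amino-4-methoxyphenyl group (a 6.4-fold higher number from compound 1 to compound 4 (0.81 log units; beyond the scatter)). The rise seen with 4-chlorophenyl is thus no longer a single case, and acetyl in place of chloro gives no separable difference (a 1.2-fold higher number from compound 2 to compound 4 (0.08 log units; within the scatter)). Nothing measured here explains the gap between these groups. On these data alone, it remains open which part of the 3-amino-4-methoxyphenyl group matters; a 3-aminophenyl or a 4-methoxyphenyl group on this carbon would separate the amine from the methoxy.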